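Ring-amine aryl change toward compound 3

The source may report more compounds than this note shows. Statements on the series, on what has been measured and on what is new or still open speak of the compounds shown alone.

Measured so far:
compound 1 `Nc1scc(CN2CCN(c3ccc(Cl)cc3Cl)CC2)c1C(=O)c1ccc(Cl)cc1`: -54%
compound 2 `Nc1scc(CN2CCN(c3cccc(C(F)(F)F)c3)CC2)c1C(=O)c1ccc(Cl)cc1`: -72%

In a functional assay on CHO cells with adenosine receptor A1 (Homo sapiens) as the target, read by cAMP accumulation and immunoassay, with a stated time of 6 min, tested at 1 uM (a higher number here means a weaker effect of the compound at the concentration tested, a lower number a stronger effect), compound 1 gives -54% and compound 2 gives -72%. Compound 2 stands lowest of the two numbers, set apart by a number 18 percentage points lower from compound 1 to compound 2 (beyond the scatter), a modest step. Compound 3 `Nc1scc(CN2CCN(c3ccccc3C(F)(F)F)CC2)c1C(=O)c1ccc(Cl)cc1` differs from compound 2 in one place: 2-(trifluoromethyl)phenyl in place of 3-(trifluoromethyl)phenyl on an amine nitrogen in a ring. Going by the values given here, no measured step moves the trifluoromethyl within the phenyl; the one known step concerns a different group swap, so it offers only weak guidance. Compound 3 is therefore expected to change little, a number 7 percentage points higher from compound 2 to compound 3 (within the scatter), within the scatter. For compound 3 the estimate is -65%, with a range from -85% to -42%.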

Compound 3, a percentage reported as activity, at one concentration (the size of the read-out at that concentration, not a potency): -39%
Estimate against measurement, compound 3: 26 percentage points below; the whole stated range lies below it.
By their numbers in this assay, from the lowest: compound 2; then compound 1; then compound 3.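

In this assay, the place of the trifluoromethyl on the phenyl matters even with the same atoms: a number 33 percentage points higher from compound 2 to compound 3 (beyond the scatter). The 2-(trifluoromethyl)phenyl also reverses the direction seen with the 3-(trifluoromethyl)phenyl relative to the 2,4-dichlorophenyl, with a number 15 percentage points higher from compound 1 to compound 3 (beyond the scatter), so the trifluoromethyl group alone does not set the read-out at this ring nitrogen. Nothing available accounts for this shift. Still open, on these data alone, is whether a nitrile or a methoxy group in place of the trifluoromethyl would also give a read-out that depends on its place on the phenyl.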